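Adding a Methoxy Group to the Weaker Core

A few compounds are considered here, and "the series" means these few. Any claim that something is new, unique, unknown or untested is made for them only; others in the source may bear on it.

Of the compounds shown here, two have been tested in a functional assay on 786-0 cells (Homo sapiens) for inhibition, read by sulforhodamine B assay, with a stated time of 48 h; a lower number here means a stronger inhibitor of growth, a higher number a weaker inhibitor of growth. Among the measured compounds shown here, compound 1 `COc1cc(OC)c(OC)cc1/C=C/C1CC=CC(=O)O1` is the one with a measured number: in this assay compound 1 gives 6 uM. Compound 2 `COc1ccc(/C=C/C2CC=CC(=O)N2)cc1OC` has a different core and a different methoxy pattern from compound 1. In this assay compound 2 gives > 964 uM, which is a limit of the assay and not a number. Compound 2 therefore stands at the limit of > 964 uM in this assay, at which 1 of the 2 values shown sits, so of the two values shown only compound 1 has a definite position. For the measured compounds named here, since compound 1 and compound 2 differ in two places at once, no single step between them can be read, and their two values show only that one compound has a number while the other does not.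

Compound 3 `COc1cc(OC)c(OC)cc1/C=C/C1CC=CC(=O)N1` differs from compound 2 by methoxy in place of hydrogen on an aromatic carbon. Its methoxy pattern now matches that of compound 1, while the core of compound 2 is kept. In this assay the expected step is an at least 2.4-fold lower number from compound 2 to compound 3 (0.38 log units; beyond the scatter), a modest gain that may not reach a measurable number. For compound 3 the estimate is 400 uM, with a range from 60 uM to 1000 uM, and a reported limit remains a real possibility.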

Compound 3, concentration for growth inhibition (reported as GI): > 864 uM
Compound 3: a limit, no number (the forecaster's own chance of this, stated with the estimate: 55%); middle value at least 2.1-fold (0.33 log units) from the limit.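

In this assay compound 3, with methoxy on this aromatic carbon, still gives no number and stands at a limit: the limit of > 864 uM in this assay, at which 1 of the 3 values shown sits. Going by these compounds, compound 2 and compound 3 both sit at limits, so the step between them cannot be read, and the size of the methoxy change on this core stays unknown. What this result adds is a clean comparison: with the methoxy pattern now matched, only the core separates the pair, and exchanging the core of compound 1 for that of compound 3 gives an at least 140-fold higher number from compound 1 to compound 3 (2.15 log units; beyond the scatter), a large step beyond the scatter, which compound 2 could not show because it differed from compound 1 in two places.

The compounds shown leave open what this methoxy contributes on the core of compound 1, where a measured number could reveal it. They also leave open whether an amine or a hydroxyl group in place of this methoxy would bring the core of compound 3 to a measured number at all.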